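The compounds below may be only part of what the source reports. "The series", "measured", "known", "first", "only" and "open" are said of these compounds alone.

Measured so far:
- compound 1, `CC(C)(C)OC(=O)N1CCC(O[C@H]2CC[C@@H](Oc3ccc(S(C)(=O)=O)cc3)CC2)CC1`: 1390 nM
- compound 2, `CC(C)(C)OC(=O)N1CCC(O[C@H]2CC[C@H](Oc3cnc(S(C)(=O)=O)cn3)CC2)CC1`: 64 nM
- compound 3, `C[C@@H](CF)OC(=O)N1CCC(O[C@H]2CC[C@H](Oc3cnc(S(C)(=O)=O)cn3)CC2)CC1`: 356 nM

In a functional assay on isolated protein for agonist activity at Glucose-dependent insulinotropic receptor (Rattus norvegicus), read by HTRF and cAMP accumulation (a lower number here means that less compound is needed, a higher number that more compound is needed for the effect), compound 3 stands second highest of the three numbers; compound 1 gives a higher number and compound 2 a lower one. Compound 4, `CS(=O)(=O)c1cnc(O[C@H]2CC[C@H](OC3CCN(C(=O)C4(C(F)(F)F)CCCC4)CC3)CC2)cn1`, differs from compound 3 in one place: a group of 9 heavy atoms (6 carbon, 3 fluorine; one five-membered non-aromatic ring of carbon only) in place of a group of 5 heavy atoms (3 carbon, 1 oxygen, 1 fluorine; no ring), on a carbonyl carbon. Among the measured compounds shown here, only one measured step touches this part of the molecule, namely a 5.6-fold higher number from compound 2 to compound 3 (0.75 log units; beyond the scatter), a change at the same carbonyl that moved this assay by a modest amount. That step shows the group on the carbonyl matters, but it does not tell how a ring-bearing group with three fluorines will behave, so the direction is uncertain. Since compound 2, with its bulkier tert-butyl group, gave 64 nM, a somewhat lower number than compound 3 seems the more likely outcome for compound 4, with a wide range; the step expected is a 2.4-fold lower number from compound 3 to compound 4 (0.38 log units; beyond the scatter), and the estimate for compound 4 in this assay is 150 nM, between 40 nM and 600 nM.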

Compound 4, half-maximal effective concentration: 108 nM
The estimate for compound 4 lay 1.4-fold (0.14 log units) above the measured number; measured number inside the range.
By their numbers in this assay, from the lowest: compounds 2 and 4 (each within the scatter of the next); then compound 3; then compound 1.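

In this assay, the group on this carbonyl carbon does not have to be joined through an oxygen: a group with no oxygen, built on a five-membered carbon ring with three fluorines, gives a 3.3-fold lower number from compound 3 to compound 4 (0.52 log units; beyond the scatter). Set against the tert-butyl group of compound 2, the same group gives a 1.7-fold higher number from compound 2 to compound 4 (0.23 log units; within the scatter), which lies within the scatter, so two quite different groups on this carbonyl cannot be told apart in this test. Nothing available explains either step in terms of a property of these groups.

On these data alone, it remains open whether the trifluoromethyl group, the five-membered ring or the two together account for the step from compound 3. How a group carrying an amine or a carboxylic acid would fare on this carbonyl is also unknown.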